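Dropping a chloro from a chloroacetamide pyridinyl series

A few compounds are considered here, and "the series" means these few. Any claim that something is new, unique, unknown or untested is made for them only; others in the source may bear on it.

Measured compounds:
- compound 1, `COc1ccccc1C(=O)Nc1nnc(SCC(=O)Nc2ccc(Cl)cn2)s1`, > 80000 nM
- compound 2, `O=C(CSc1nnc(NC(=O)CCl)s1)Nc1ccc(Br)cn1`, 3400 nM
- compound 3, `O=C(CCl)Nc1ccc(SCC(=O)Nc2ccc(Cl)cn2)cc1`, 2500 nM

Of the compounds shown here, three have been tested in a functional assay on HeLa cells (Homo sapiens) for antiproliferative activity, read by MTT assay, with a stated time of 48 h; on this read-out higher numbers stand for weaker inhibition and lower numbers for stronger inhibition. For compound 1 the result is a limit of the assay rather than a number, as the limit of > 80000 nM in this assay, at which 1 of the 3 values shown sits, records. Compound 2 gives 3400 nM. Compound 3 gives 2500 nM, the lowest of the two numbers, though its gap to compound 2 lies within the scatter, so the two cannot be ranked against each other.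

The next compound, compound 4, `O=C(CCl)Nc1ccc(SCC(=O)Nc2ccccn2)cc1`, has not yet been measured. It differs from compound 3 in one place: hydrogen in place of chloro on an aromatic carbon of the six-membered aromatic ring with one nitrogen, two atoms from the ring nitrogen, para to a large group. Read one bond further out, the 5-chloropyridin-2-yl becomes pyridin-2-yl.

Within the data shown here, no measured pair here shows this kind of change, so there is no step to lean on. The expectation is a small step, if any, from compound 3 to compound 4 in this assay, probably toward weaker inhibition but not clearly beyond the scatter: a 1.6-fold higher number from compound 3 to compound 4 (0.20 log units; within the scatter). Compound 4 is therefore estimated at 4000 nM, with a likely range from 1500 nM to 12000 nM.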

Compound 4, half-maximal inhibitory concentration: 7800 nM
Estimate against measurement, compound 4: 2.0-fold (0.29 log units) below, within the range that was stated.
By their numbers in this assay, from the lowest: compounds 3 and 2 (each within the scatter of the next); then compound 4. At a limit, above all of these: compound 1.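

In this assay, among these compounds, the change from 5-chloropyridin-2-yl to pyridin-2-yl gives the first single-place comparison: a 3.1-fold higher number from compound 3 to compound 4 (0.49 log units; beyond the scatter). The chloro on this aromatic carbon, two atoms from the ring nitrogen and para to a large group, therefore makes a real but modest difference to the read-out, since the step is larger than the usual scatter of repeated measurements and points toward weaker inhibition, while compound 4 still gives a measured 7800 nM. No measured property shown here accounts for this step.

With only chloro and hydrogen compared at this position, the compounds shown leave open how a methyl, a nitrile or an amine on the same aromatic carbon would read, and so whether the chloro is special or any group there would serve. Equally open, from the compounds shown here alone, is how a plain acetamide in place of the chloroacetamide would read on compound 3 and on compound 4, and whether the step seen here would keep its size without that group.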